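A Bromo Group Leaves, and a Phenethyl Arrives

The source may hold more compounds than are shown below. What is called first, only, known or untested is meant among the compounds shown, and "the series" means these compounds.

Of the compounds shown here, three sharing one core have been measured in a functional assay on HCT-116 cells (Homo sapiens) for inhibition, read by CCK-8 assay, with a stated time of 72 h, tested at 2 uM; a lower number here means less inhibition of growth, a higher number more inhibition of growth at the concentration tested. Compound 1 `COc1ccc(SCc2ccc(C(=O)Nc3ccccc3N)cc2)cc1` gives 73.3% and compound 2 `Cc1ccc(SCc2ccc(C(=O)Nc3ccccc3N)cc2)cc1` gives 74.8%. The step between this pair, with methyl in place of methoxy, is a number 1.5 percentage points higher from compound 1 to compound 2 (within the scatter). Compound 3 `Nc1ccccc1NC(=O)c1ccc(CSc2ccc(Br)cc2)cc1` stands lowest of the three at 9.96%.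

Compound 4 `Nc1ccccc1NC(=O)c1ccc(CSCCc2ccccc2)cc1` has not yet been measured. It differs from compound 3 by phenethyl in place of 4-bromophenyl on a sulfur. Within the data shown here, two measured steps bear most closely on this change, since both introduce the bromo group that compound 4 lacks. Bromo in place of methoxy gave a number 63.3 percentage points lower from compound 1 to compound 3 (beyond the scatter), and bromo in place of methyl gave a number 64.8 percentage points lower from compound 2 to compound 3 (beyond the scatter). Both steps are large, so removing the bromo group could recover much of the lost growth inhibition. However, no measured compound carries phenethyl, and the data contain no direct guide to its effect. Only a partial recovery is therefore expected, with wide uncertainty. The expected change is a number 35 percentage points higher from compound 3 to compound 4 (beyond the scatter). Compound 4 is estimated at 45%, with an expected range from 12% to 78%.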

Compound 4, percent growth inhibition at one concentration: 30.5%
Estimate against measurement, compound 4: 14.5 percentage points above; the measured number falls inside the stated range.
By their numbers in this assay, from the lowest: compound 3; then compound 4; then compounds 1 and 2 (each within the scatter of the next).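

Among these compounds, until now every compound carried a substituted phenyl ring on the sulfur, and in this assay phenethyl is the first group to break that pattern: in place of 4-bromophenyl it gives a number 20.5 percentage points higher from compound 3 to compound 4 (beyond the scatter), in place of 4-methylphenyl it gives a number 44.3 percentage points lower from compound 2 to compound 4 (beyond the scatter), and in place of 4-methoxyphenyl it gives a number 42.8 percentage points lower from compound 1 to compound 4 (beyond the scatter). Compound 4 has no bromine and still stands well short of compounds 1 and 2, so among these four compounds, bromine is not the only group on the sulfur that goes with a low number, and a ring held on a saturated chain can keep part of the growth inhibition. Nothing available here explains why these groups differ.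

From the compounds shown here alone, it remains open whether the length of the chain matters, which a benzyl group or a longer 3-phenylpropyl group on the sulfur could help to show. Going by these compounds, it is also open whether a methyl or methoxy group on the ring of the phenethyl would raise the number towards those of compounds 1 and 2.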